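Fluoro-to-chloro swap on the shared core, second pair

This account rests on a few compounds, and the source may have more. Where it says the series, first, only, none or still open, it means among the compounds named here.

Measured so far:
Compound 1, `CS(=O)(=O)C[C@H]1O[C@@H](n2cnc3c(N)nc(F)nc32)[C@H](O)[C@@H]1O`, in an ADME assay on L6 cells (Rattus norvegicus) for inhibition, read by resazurin assay, with a stated time of 72 h (on this read-out higher numbers stand for weaker inhibition and lower numbers for stronger inhibition), gives 5000 nM.
Compound 2, `CS(=O)(=O)C[C@H]1O[C@@H](n2cnc3c(N)nc(Cl)nc32)[C@H](O)[C@@H]1O`, in this assay gives 156000 nM.
Compound 3, `CC(=O)O[C@@H]1[C@H](OC(C)=O)[C@@H](CN=[N+]=[N-])O[C@H]1n1cnc2c(N)nc(F)nc21`, in this assay gives 18000 nM.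

Going by the values given here, the one counted step is chloro in place of fluoro on an aromatic carbon, and it gave a 31-fold higher number from compound 1 to compound 2 (1.49 log units; beyond the scatter). Compound 3 belongs to a second core; the difference between the two cores is not broken down here, and compound 3 stands between compound 1 and compound 2 in this assay.

Compound 4, `CC(=O)O[C@@H]1[C@H](OC(C)=O)[C@@H](CN=[N+]=[N-])O[C@H]1n1cnc2c(N)nc(Cl)nc21`, is not yet measured. It carries the same change as before, (chloro in place of fluoro on an aromatic carbon), with the place worded identically. Among the compounds with values here, because compound 1 to compound 2 gave a 31-fold higher number from compound 1 to compound 2 (1.49 log units; beyond the scatter), a step of similar direction and size is expected, a 22-fold higher number from compound 3 to compound 4 (1.35 log units; beyond the scatter), with wide uncertainty since only one instance of the change is measured. The estimate for compound 4 is 400000 nM, between 100000 nM and 1500000 nM.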

Compound 4, half-maximal inhibitory concentration: 141000 nM
Compound 4: middle estimate off by 2.8-fold (0.45 log units), on the high side, within the range that was stated.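

In this assay the chloro in place of fluoro swap again gives a higher number on the second core (a 7.8-fold higher number from compound 3 to compound 4 (0.89 log units; beyond the scatter)), so the direction of the change carries over across the two cores shown. The size does not carry over unchanged: the same change on two cores in this assay, a 31-fold higher number (1.49 log units; beyond the scatter) from compound 1 to compound 2 and a 7.8-fold higher number (0.89 log units; beyond the scatter) from compound 3 to compound 4, 4.0-fold (0.60 log units) apart, beyond the scatter of two such steps.
Two cores set no rule for the size of the step on a further core, and they do not show what in the cores sets it.

Still open, from the compounds shown here alone, is how a bromo or a methyl group on the same aromatic carbon would compare with fluoro and chloro. Going by these compounds, the two cores differ in more than one place, so the part of the core tied to the smaller step also stays open.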